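The compounds below may be only part of what the source reports. "The series", "measured", "known", "first", "only" and "open" are said of these compounds alone.

Working notes on the series. Compound 1 `COc1nn2cc(-c3cc4ccccc4o3)nc2s1` stands highest of the three compounds measured in an ADME assay on microsomes from liver (Homo sapiens) for metabolic stability, with a stated time of 10 min; on this read-out higher numbers stand for a more stable compound and lower numbers for a less stable compound: compound 1 gives 80%. Compound 2 `COc1nn2cc(-c3cc4cccc(OC)c4o3)nc2s1` gives 25%, and compound 3 `CCSc1nn2cc(-c3cc4ccccc4o3)nc2s1` gives 45%. Both measured steps away from compound 1 run downward and beyond the scatter: a number 55 percentage points lower from compound 1 to compound 2 (beyond the scatter), and a number 35 percentage points lower from compound 1 to compound 3 (beyond the scatter).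

Compound 4 `COc1ccc2oc(-c3cn4nc(OC)sc4n3)cc2c1` is not yet measured. It differs from compound 1 in a single place: methoxy in place of hydrogen on an aromatic carbon. Within the data shown here, of the two measured steps, the one from compound 1 to compound 2 bears on this change, since it is the same kind of entry of methoxy in place of hydrogen on an aromatic carbon of the same core, though on a different aromatic carbon of the six-membered aromatic ring of carbon only; that step was large, a number 55 percentage points lower from compound 1 to compound 2 (beyond the scatter). The step from compound 1 to compound 3 is a different change and only shows that a single substitution on this core can move the read-out well beyond the scatter.

Among the measured compounds shown here, a downward step is therefore expected for compound 4 in this assay, a number 40 percentage points lower from compound 1 to compound 4 (beyond the scatter), with the size left uncertain because the only precedent, a number 55 percentage points lower from compound 1 to compound 2 (beyond the scatter), concerns another place on the ring. Compound 4 is estimated at 40%, in the range 15% to 70%.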

Compound 4, percent of the compound remaining: 30%
Estimate against measurement, compound 4: 10 percentage points above; measured number inside the range.
By their numbers in this assay, from the lowest: compounds 2 and 4 (each within the scatter of the next); then compound 3; then compound 1.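

In this assay, methoxy in place of hydrogen at this place, on the six-membered aromatic ring of carbon only, meta to a fused ring and para to a fused ring, also gives a large fall: a number 50 percentage points lower from compound 1 to compound 4 (beyond the scatter). The loss on entry of methoxy is thus no longer tied to a single carbon of that ring, since two different carbons now carry the group, and compound 2 at 25% and compound 4 at 30% lie within the scatter of each other, with neither of these two compounds going against the pattern. Nothing available on the series speaks to what lies behind the fall.

The compounds shown leave open whether the fall belongs to methoxy itself or would follow other groups at this place, such as a fluorine atom, a hydroxyl or an amine, and whether a longer chain such as ethoxy would behave alike. They also leave open how the remaining carbons of the ring respond to the same change, and whether ethylsulfanyl on the core would combine with methoxy on the ring.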